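Benzyl for cyclopropyl on the chain beside the charged nitrogen

This account rests on a few compounds, and the source may have more. Where it says the series, first, only, none or still open, it means among the compounds named here.

Three salts sharing one core have been measured in a physicochemical assay for solubility; a lower number here means a less soluble compound, a higher number a more soluble compound. Compound 1 `CC[n+]1ccc(CCC(=O)c2cc3cc(OC)c(OC)cc3s2)cc1` gives 25000 ug/mL. Compound 2 `CCC[n+]1ccc(CCC(=O)c2cc3cc(OC)c(OC)cc3s2)cc1` gives 16000 ug/mL. Compound 3 `COc1cc2cc(C(=O)CCc3cc[n+](CC4CC4)cc3)sc2cc1OC` gives 15000 ug/mL. Compound 3 holds the lowest of the three numbers, yet the step of a 1.7-fold lower number from compound 1 to compound 3 (0.22 log units; within the scatter) and the step of a 1.1-fold lower number from compound 2 to compound 3 (0.03 log units; within the scatter) both stay within the scatter, so the three compounds cannot be ordered. Compound 4 `COc1cc2cc(C(=O)CCc3cc[n+](Cc4ccccc4)cc3)sc2cc1OC` differs from compound 3 by phenyl in place of cyclopropyl on a saturated chain carbon bound to an aromatic nitrogen. Going by the values given here, the steps that bear on this place are a 1.7-fold lower number from compound 1 to compound 3 (0.22 log units; within the scatter) and a 1.1-fold lower number from compound 2 to compound 3 (0.03 log units; within the scatter), both small, and they involve only small saturated groups. Phenyl is a larger, aromatic group, and no measured step covers such a change at this place, so the expectation rests on the direction of the small steps already seen there. The writer expects a moderate decrease for compound 4, a 2.1-fold lower number from compound 3 to compound 4 (0.33 log units; beyond the scatter), and estimates compound 4 at 7000 ug/mL, within a range from 2500 ug/mL to 18000 ug/mL.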

Compound 4, solubility: 2000 ug/mL
Compound 4: middle estimate off by 3.5-fold (0.54 log units), on the high side; measured number below the stated range.
By their numbers in this assay, from the lowest: compound 4; then compounds 3, 2 and 1 (each within the scatter of the next).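

In this assay, going by these compounds alone, the change from cyclopropylmethyl to benzyl is the first at this place, on a saturated chain carbon bound to an aromatic nitrogen, to go beyond the scatter: the result is a 7.5-fold lower number from compound 3 to compound 4 (0.88 log units; beyond the scatter), and the same group gives an 8.0-fold lower number from compound 2 to compound 4 (0.90 log units; beyond the scatter) and a 13-fold lower number from compound 1 to compound 4 (1.10 log units; beyond the scatter) against the two smaller chains. The number at this place therefore does move with the group on that carbon, whereas the small saturated groups of compounds 1, 2 and 3 left their numbers within the scatter of one another. Nothing measured here accounts for the drop, which stands as an observation only.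

On these data alone, it remains open whether the aromatic ring or the larger count of carbons goes with the lower number, a question a cyclohexyl group at the same place would address. Also open, as far as these compounds go, is how a phenyl ring carrying a carboxylic acid or an amine would read.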